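A methyl on the hydroxycarbamoyl nitrogen of compound 1

A few compounds are considered here, and "the series" means these few. Any claim that something is new, unique, unknown or untested is made for them only; others in the source may bear on it.

Compound 1 `O=C(NO)c1cc2ccn(Cc3ccc(F)cc3F)c2cn1` is the starting point. In an ADME assay on CEM-SS cells (Homo sapiens) for cytotoxicity, read by XTT assay (on this read-out lower numbers stand for higher toxicity in this test and higher numbers for lower toxicity in this test), compound 1 gives > 320000 nM, which is a limit and not a number. Compound 2 `O=C(NO)c1cc2ccn(Cc3ccc(F)cc3)c2cn1` gives a true number, 159000 nM. Compound 3 `NC(=O)c1cc(F)ccc1Cn1ccc2cc(C(=O)NO)ncc21` gives > 10000 nM, again only a limit.

Compound 4 `CN(O)C(=O)c1cc2ccn(Cc3ccc(F)cc3F)c2cn1` keeps the core of compound 1 but has methyl in place of hydrogen on an amide-type nitrogen, so hydroxycarbamoyl becomes hydroxy(methyl)carbamoyl: methyl in place of hydrogen on an amide-type nitrogen.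

Going by the values given here, no measured step touches that nitrogen. All of them change an aromatic carbon, so they are only loose guides. Hydrogen in place of fluoro gave an at least 2.0-fold lower number from compound 1 to compound 2 (0.30 log units; that floor lies within the scatter). Carbamoyl in place of fluoro gave a step that the two limits leave unreadable from compound 1 to compound 3, and carbamoyl in place of hydrogen gave a step that the limit leaves unreadable from compound 2 to compound 3. Among the compounds with values here, the one step with a readable size is therefore small, and a similarly modest change is expected here, perhaps none beyond the scatter. The estimated change is an at least 1.2-fold lower number from compound 1 to compound 4 (0.10 log units; that floor lies within the scatter), with its direction uncertain. For compound 4 the expected value is 250000 nM, with an estimated range of 80000 nM to 500000 nM.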

Compound 4, half-maximal cytotoxic concentration: 135000 nM
Estimate against measurement, compound 4: 1.9-fold (0.27 log units) above; measured number inside the range.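

Methyl in place of hydrogen on the amide-type nitrogen gives an at least 2.3-fold lower number from compound 1 to compound 4 (0.37 log units; beyond the scatter), the first step in this set shown to lie beyond the scatter in this assay. On this read-out a lower number stands for higher toxicity in this test, so this one added carbon moves the result towards higher toxicity. Compound 1 stands at a limit and not at a number, so the step is only a floor and its true size stays open: the limit of > 320000 nM in this assay, at which 1 of the 4 values shown sits.

From the compounds shown here alone, whether the same change would act alike on compound 2, which carries one fluoro fewer, stays open. Also open, going by these compounds, is whether ethyl or a longer chain on that nitrogen would shift the number further, and whether the loss of the hydrogen or the gain of the methyl drives the step.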